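The source may hold more compounds than are shown below. What is called first, only, known or untested is meant among the compounds shown, and "the series" means these compounds.

The compounds gathered here share one core: an indole bearing, at its two-position, a carbonyl that carries a pyridin-3-ylmethyl group, with varied substitution on the benzo ring. Compound 1 `O=C(Cc1cccnc1)c1cc2c(F)cccc2[nH]1` carries a fluoro substituent, compound 2 `O=C(Cc1cccnc1)c1cc2cc(Br)ccc2[nH]1` a bromo substituent, and compound 3 `c1cncc(CCc2cc3ccccc3[nH]2)c1` lacks the carbonyl altogether, joining the pyridine to the indole through a two-carbon chain.

In an assay on isolated protein for inhibition of Indoleamine 2,3-dioxygenase 1 (Homo sapiens), read by spectrophotometry (on this read-out higher numbers stand for weaker inhibition and lower numbers for stronger inhibition), compound 2 gives 18000 nM, the lowest of the two numbers recorded. In this assay compound 1 gives 153000 nM, a larger number, and the gap between the two lies beyond the scatter. Compound 3 is reported in this assay as "not active" (no number reported), with no number attached.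

The next compound, compound 4 `COc1ccc2[nH]c(C(=O)Cc3cccnc3)cc2c1`, differs from compound 2 in one place: methoxy in place of bromo on an aromatic carbon. Methoxy replaces bromo, and nothing else about the molecule changes. Among the measured compounds shown here, no measured pair in this set isolates such a swap, so there is no step to lean on. Compound 4 is expected to lose some ground relative to compound 2, with a step of a 2.2-fold higher number from compound 2 to compound 4 (0.35 log units; beyond the scatter) toward a weaker inhibition. The estimate for compound 4 in this assay is 40000 nM, expected to fall between 10000 nM and 160000 nM.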

Compound 4, half-maximal inhibitory concentration: 49000 nM
Beside the measured number, compound 4's estimate is 1.2-fold (0.09 log units) below it; the range from low to high includes it.
By their numbers in this assay, from the lowest: compound 2; then compound 4; then compound 1.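

In this assay, among the compounds shown here, exchanging bromo for methoxy on this aromatic carbon gives a 2.7-fold higher number from compound 2 to compound 4 (0.43 log units; beyond the scatter) and so provides the first step in the set that isolates a single change, showing that the number responds to which group sits at this place. The step is modest yet beyond the scatter, and compound 4 still gives a measurable number on this read-out, so methoxy weakens inhibition without abolishing it. Methoxy brings one hydrogen-bond acceptor and one more heavy atom than bromo, but this brings no gain here, and no measurement at hand accounts for the difference between the two groups.

The compounds shown leave open how a plain hydrogen, chloro, an amine or a carboxylic acid would fare at this same place, and with only two groups compared here, a single step does not yet make a trend. They also leave open whether the same exchange of bromo for methoxy would give a step of similar size on another carbon of the six-membered ring.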